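This account rests on a few compounds, and the source may have more. Where it says the series, first, only, none or still open, it means among the compounds named here.

Measured compounds in a functional assay on HCT-116 cells (Homo sapiens) for cytotoxicity, with a stated time of 3 days; on this read-out lower numbers stand for stronger inhibition and higher numbers for weaker inhibition:
Compound 1 `C#Cc1nc(C(=O)OCC)cs1` gives > 40000 nM, a limit of the assay and not a number.
Compound 2 `C#CCNC(=O)c1csc(Br)n1` gives > 40000 nM, likewise a limit of the assay.
Compound 3 `C=Cc1nc2ccccc2o1` gives > 40000 nM, again a limit of the assay.

Compound 2 therefore stands at the limit of > 40000 nM in this assay, at which 3 of the 3 values shown sit, so none of the three values separates it from the others in this assay. Compound 4 `C#CCNC(=O)c1cscn1` differs from compound 2 in one place: hydrogen in place of bromo on an aromatic carbon. For the measured compounds named here, with no measured step to rest on, the author expects the change from compound 2 to compound 4 to bring no shift beyond the scatter in this assay, most likely another limit. The estimated step is a step that the limit leaves unreadable from compound 2 to compound 4. Compound 4 is expected at 60000 nM, within a range from 20000 nM to 200000 nM.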

Compound 4, half-maximal inhibitory concentration: > 40000 nM
Compound 4 ended at the assay's limit; the forecaster's own chance of this, stated with the estimate: 85%; the middle value lies beyond the limit too.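

Compound 2 and compound 4 both rest at a limit of the assay, so the step between them cannot be read: the limit of > 40000 nM in this assay, at which 4 of the 4 values shown sit.

The compounds shown leave open whether bromo or hydrogen at that place makes any difference in this assay, as none of them gives a number.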